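Cytotoxicity limits across four close analogues

The source may report more compounds than this note shows. Statements on the series, on what has been measured and on what is new or still open speak of the compounds shown alone.

Compound 1 `CCOC(=O)c1c(-c2cccc(-c3ccccc3)c2)[nH]c2cc(Cl)c(OC)cc2c1=O` and compound 2 `CCOC(=O)c1c(-c2cccc(OC)c2)[nH]c2cc(Cl)c(OC)cc2c1=O` share one core and differ by methoxy in place of phenyl on an aromatic carbon. In an ADME assay on Raji cells (Homo sapiens) for cytotoxicity, read by luminescence, with a stated time of 72 h (on this read-out lower numbers stand for an effect already at smaller amounts and higher numbers for an effect only at larger amounts of compound), compound 1 reaches only the limit of the assay, > 21500 nM. Compound 2 likewise gives only the limit > 21500 nM. The step that the two limits leave unreadable from compound 1 to compound 2 cannot be sized, since both values sit at the limit of > 21500 nM in this assay, at which 3 of the 3 values shown sit. Compound 3 `CCOC(=O)c1c(-c2cccc(-c3ccccc3)c2)[nH]c2cc(OC)c(Cl)cc2c1=O` has the same atoms as compound 1 joined differently; the difference between the two cores is not broken down here. Compound 3 also gives only the limit > 21500 nM in this assay. Compound 4 `CCOC(=O)c1c(-c2cccc(OC)c2)[nH]c2cc(OC)c(Cl)cc2c1=O` is not yet measured; it differs from compound 3 by methoxy in place of phenyl on an aromatic carbon, the same change as between compound 1 and compound 2. For compound 4 the expected step is a step that the limit leaves unreadable from compound 3 to compound 4, resting on the unreadable a step that the two limits leave unreadable from compound 1 to compound 2 and on (the limit of > 21500 nM in this assay, at which 3 of the 3 values shown sit). Compound 4 is therefore estimated at 30000 nM in this assay, most likely again only a limit.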

Compound 4, half-maximal effective concentration: > 21500 nM
Compound 4 was reported as a limit (the forecaster's own chance of this, stated with the estimate: 85%); the middle value does not contradict the limit.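

Compound 3 and compound 4 both give only a limit in this assay, so no step between them can be read: the limit of > 21500 nM in this assay, at which 4 of the 4 values shown sit.

The compounds shown leave open whether methoxy in place of phenyl changes this read-out at all, and where any of the four would give an actual number.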